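A few compounds are considered here, and "the series" means these few. Any claim that something is new, unique, unknown or untested is made for them only; others in the source may bear on it.

In an assay (Homo sapiens) for inhibition of Nucleic Acid (a higher number here means a weaker inhibitor, a lower number a stronger inhibitor), three compounds that share one core have been tested. Compound 1 (`O=c1cc([Se]c2ccccc2)n(COCCO)c(=O)[nH]1`) gives > 100000 nM, which is a limit of the assay and not a number. Compound 2 (`Cc1c([Se]c2ccccc2)n(COCCO)c(=O)[nH]c1=O`) gives > 100000 nM, again a limit. Compound 3 (`O=c1[nH]c(=O)n(COCCO)c([Se]c2ccccc2)c1Cl`) gives > 100000 nM, also a limit, so it stands with no exact number. Taken together, the data show (the limit of > 100000 nM in this assay, at which 3 of the 3 values shown sit).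

Compound 4 (`O=c1[nH]c(=O)n(COCCO)c([Se]c2ccccc2)c1Br`) differs from compound 3 by bromo in place of chloro on an aromatic carbon. For the measured compounds named here, three measured steps bear on this change: a step that the two limits leave unreadable from compound 1 to compound 2, a step that the two limits leave unreadable from compound 1 to compound 3 and a step that the two limits leave unreadable from compound 2 to compound 3. None of them has a readable size, so they give no direction and no measure for a new swap on this carbon. Compound 3 has only its limit of > 100000 nM as a starting point, so no step beyond the scatter is expected in this assay. The expected change is a step that the limit leaves unreadable from compound 3 to compound 4, and a reported limit is the likeliest result. For compound 4 the estimated value is 120000 nM, with an expected range from 50000 nM to 300000 nM.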

Compound 4, half-maximal inhibitory concentration: > 100000 nM
Compound 4: no number, only a limit; the forecaster's own chance of this, stated with the estimate: 90%; the middle value lies beyond the limit too.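

In this assay compound 4 gives > 100000 nM, which is a limit and not a number. Its steps from compound 1, compound 2 and compound 3 therefore cannot be read: the limit of > 100000 nM in this assay, at which 4 of the 4 values shown sit. The compounds shown leave open whether any group on this aromatic carbon of the shared core gives a measurable value.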